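A few compounds are considered here, and "the series" means these few. Any claim that something is new, unique, unknown or untested is made for them only; others in the source may bear on it.

Measured so far in a functional assay on MCF7 cells (Homo sapiens) for inhibition, read by MTT assay, with a stated time of 5 days; a lower number here means a stronger inhibitor, a higher number a weaker inhibitor:
compound 1 `Cc1cc(Nc2nc(NCc3ccccc3F)nc3[nH]ncc23)n[nH]1`, 2310 nM
compound 2 `Cc1cc(Nc2nc(NCc3ccc(Cl)cc3)nc3[nH]ncc23)n[nH]1`, 860 nM

Among the measured compounds shown here, the only completed step, a 2.7-fold lower number from compound 1 to compound 2 (0.43 log units; beyond the scatter), changes the group on the chain carbon attached to the ring nitrogen. Compound 2 thus holds the lower of the two numbers in this assay, with compound 1 the higher by that step.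

Compound 3 `Cc1cc(Nc2nc(NCc3ccc(Cl)cc3)nc3c2cnn3C2CCOCC2)n[nH]1` differs from compound 2 at another site: oxan-4-yl in place of hydrogen on an aromatic nitrogen. For the measured compounds named here, no measured pair touches this position, so the single step between compound 1 and compound 2 gives no guide to the size or direction of the change here. With nothing to lean on, a step of no more than modest size in either direction is expected, a 1.4-fold higher number from compound 2 to compound 3 (0.14 log units; within the scatter), and the estimate for compound 3 in this assay is 1200 nM, within a wide range from 300 nM to 5000 nM.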

Compound 3, half-maximal inhibitory concentration: 1550 nM
Beside the measured number, compound 3's estimate is 1.3-fold (0.11 log units) below it; the measured number falls inside the stated range.
By their numbers in this assay, from the lowest: compounds 2, 3 and 1 (each within the scatter of the next, the first and the last beyond it).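

At the aromatic nitrogen, oxan-4-yl takes the place of hydrogen, and this assay records a 1.8-fold higher number from compound 2 to compound 3 (0.26 log units; within the scatter), so this assay does not separate compound 2 from compound 3. The position therefore carries one six-membered non-aromatic ring with 1 hetero atom, 6 heavy atoms in all, with no step beyond the scatter, which the change on the chain carbon could not show. Nothing available explains why the two compounds read alike.

One group on this nitrogen cannot show whether others, such as a methyl group, a piperidine amine or a carboxylic acid, would read the same. Going by these compounds, it also remains open whether oxan-4-yl would give a similar step alongside the 2-fluorophenyl group of compound 1.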